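Changing the Hydroxycarbamoyl End of a Chain

The source may report more compounds than this note shows. Statements on the series, on what has been measured and on what is new or still open speak of the compounds shown alone.

Going by the values given here, in a functional assay on Hep 3B2 cells (Homo sapiens) for inhibition, read by MTT assay, with a stated time of 72 h (on this read-out higher numbers stand for weaker inhibition and lower numbers for stronger inhibition), compound 1 `Nc1nc2cc(-c3nn(CCCCCCCCCC(=O)NO)c4ncnc(N)c34)ccc2o1` gives 28800 nM and compound 2 `Nc1nc2cc(-c3nn(CCCCC(=O)NO)c4ncnc(N)c34)ccc2o1` gives 33700 nM, so compound 2 stands level with the only other measured compound. Compound 3 `CNC(=O)CCCCCCCn1nc(-c2ccc3oc(N)nc3c2)c2c(N)ncnc21` has not yet been measured, and it differs from compound 2 in one place: 3-(methylcarbamoyl)propyl in place of hydroxycarbamoyl on a saturated chain carbon, four bonds along the chain from an aromatic nitrogen. The change is 3-(methylcarbamoyl)propyl in place of hydroxycarbamoyl on a saturated chain carbon, four bonds along the chain from an aromatic nitrogen. Among the compounds with values here, only one measured step bears on this: a 1.2-fold higher number from compound 1 to compound 2 (0.07 log units; within the scatter). Going by these compounds, both of its compounds keep the hydroxycarbamoyl end, so it says something about chain length but nothing about losing that end, which remains untested. A modest move towards a higher number is therefore expected, with a 1.3-fold higher number from compound 2 to compound 3 (0.13 log units; within the scatter) as the estimated step. Compound 3 is estimated at 45000 nM, within an expected range of 18000 nM to 110000 nM.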

Compound 3, half-maximal inhibitory concentration: 10300 nM
Estimate against measurement, compound 3: 4.4-fold (0.64 log units) above; the measured number lies below the stated range.
By their numbers in this assay, from the lowest: compound 3; then compounds 1 and 2 (each within the scatter of the next).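

Losing the hydroxycarbamoyl end does not weaken inhibition in this assay, as the opening estimate assumed it might; putting 3-(methylcarbamoyl)propyl in its place gives a 3.3-fold lower number from compound 2 to compound 3 (0.51 log units; beyond the scatter). The step from the other measured hydroxycarbamoyl compound agrees: with methylcarbamoyl in place of 2-(hydroxycarbamoyl)ethyl, the result is a 2.8-fold lower number from compound 1 to compound 3 (0.45 log units; beyond the scatter). So, among these three compounds, the end group at this position matters more than the chain change between compound 1 and compound 2, and the hydroxycarbamoyl end is not needed for the activity seen here, though nothing measured so far gives a reason for this shift.

Going by these compounds, whether the gain belongs to the methylcarbamoyl end itself or to the longer chain that compound 3 carries compared with compound 2 remains open. Also open, on these data alone, is how other ends, such as a carboxylic acid or an amine, would behave on a chain of this kind.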